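Stability notes: phenyl in place of cyclopropyl on the core

The source may report more compounds than this note shows. Statements on the series, on what has been measured and on what is new or still open speak of the compounds shown alone.

Measured so far in an ADME assay on microsomes from liver (Mus musculus), read by LC-MS, using NADPH, with a stated time of 30 min, tested at 1 uM; a higher number here means that more of the compound is left, a lower number that less of the compound is left:
- compound 1 `Cc1nc(N)c(C#N)c(N[C@@H](C)c2cc3ccc(F)cn3c(=O)c2-c2ccccc2)n1`: "not determined" (no result reported)
- compound 2 `C[C@H](Nc1ncnc(N)c1C#N)c1c(C2CC2)c(=O)n2cc(F)ccc2c1-c1ccc(F)cc1`: 52%
- compound 3 `C[C@H](Nc1nc(N)nc(N)c1C#N)c1c(C2CC2)c(=O)n2cc(F)ccc2c1-c1ccc(F)cc1`: 75%

For the measured compounds named here, compound 3 has the highest of the two numbers in this assay; the nearest is compound 2, and the one step that connects them, a number 23 percentage points higher from compound 2 to compound 3 (beyond the scatter), lies beyond the scatter. Compound 1 carries no number and cannot be placed.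

Compound 4 `C[C@H](Nc1nc(N)nc(N)c1C#N)c1c(-c2ccccc2)c(=O)n2cc(F)ccc2c1-c1ccc(F)cc1` is the next entry. Against compound 3 the change is phenyl in place of cyclopropyl on an aromatic carbon; the two amino groups on the pyrimidine of compound 3 are kept.

Going by the values given here, no measured step bears on this change. Among the compounds with values here, the only step in hand, from compound 2 to compound 3, concerns an amino group on a different ring and says nothing about the group exchanged here. Compound 1, the one measured entry with a phenyl at this place, has no number. The expectation therefore rests on compound 3 alone, with a wide range: no step beyond the scatter is assumed, and the estimated step of a number 10 percentage points lower from compound 3 to compound 4 (within the scatter) is meant as a small drift rather than a direction. For compound 4 the estimate in this assay is 65%, within 35% to 90%.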

Compound 4, percent of the compound remaining: 83%
Compound 4: the middle estimate sits 18 percentage points below what was measured, and the stated range covers the measured number.
By their numbers in this assay, from the lowest: compound 2; then compounds 3 and 4 (each within the scatter of the next).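

In this assay, phenyl in place of cyclopropyl on this aromatic carbon, two atoms from the ring nitrogen, gives a number 8 percentage points higher from compound 3 to compound 4 (within the scatter), so exchanging a three-membered non-aromatic ring for a six-membered aromatic ring of carbon only produces no step beyond the scatter. For the compounds shown here, this is the first reading of any change at this place, since the earlier step concerned an amino group on a different ring and compound 1, which also carries phenyl here, has no usable number. Nothing measured on these compounds accounts for the result, so it stands as an observation only.

Going by these compounds alone, how an amine, a carboxylic acid or a longer chain on this aromatic carbon would read in this assay remains open, since cyclopropyl and phenyl are the only groups with numbers here and both are hydrocarbon rings. Within the data shown here, also open is whether the phenyl exchange would read the same without the added amino group that separates compound 2 from compound 3, as the only phenyl reading comes with both amino groups in place.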